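Triazole series with trimethoxyphenyl: alkoxyphenyl variations

A few compounds are considered here, and "the series" means these few. Any claim that something is new, unique, unknown or untested is made for them only; others in the source may bear on it.

Compound 1 `COc1cccc(-c2ncnn2-c2cc(OC)c(OC)c(OC)c2)c1` carries a 3-methoxyphenyl on the shared core. In a functional assay on HL-60 cells (Homo sapiens) for antiproliferative activity, read by MTT assay, with a stated time of 72 h (a lower number here means a stronger inhibitor, a higher number a weaker inhibitor), compound 1 reaches only the limit > 10000 nM. Compound 2 `CCOc1cccc(-c2ncnn2-c2cc(OC)c(OC)c(OC)c2)c1` differs from compound 1 by methyl in place of hydrogen on a saturated chain carbon bound to an oxygen on an aromatic ring. In this assay compound 2 likewise stops at the limit > 10000 nM. The step that the two limits leave unreadable from compound 1 to compound 2 therefore cannot be sized. Compound 3 `COc1ccccc1-c1ncnn1-c1cc(OC)c(OC)c(OC)c1` differs from compound 1 by 2-methoxyphenyl in place of 3-methoxyphenyl on an aromatic carbon, and the difference between the two cores is not broken down further here. In this assay compound 3 also returns only the limit > 10000 nM, so the step that the two limits leave unreadable from compound 1 to compound 3 stays unreadable. All three values sit at the limit of > 10000 nM in this assay, at which 3 of the 3 values shown sit.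

Compound 4 `CCOc1ccccc1-c1ncnn1-c1cc(OC)c(OC)c(OC)c1` remains to be measured. It differs from compound 3 by methyl in place of hydrogen on a saturated chain carbon bound to an oxygen on an aromatic ring, which is the same change as that from compound 1 to compound 2, at the same place. Beside the unreadable step from compound 1 to compound 2, the step that the limit leaves unreadable from compound 3 to compound 4 from compound 3 to compound 4 is expected to be unreadable in the same way, resting on compound 3 sitting at > 10000 nM and compound 2 at > 10000 nM. Compound 4 is expected to give about 15000 nM in this assay, most likely reported again as a limit.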

Compound 4, half-maximal inhibitory concentration: > 10000 nM
Compound 4: only a limit was reported; the forecaster's own chance of this, stated with the estimate: 85%; the middle value is on the limit's open side.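

Among these compounds, compound 4 gives only a limit in this assay, > 10000 nM, so no step to it from compound 3 can be read. The series stays flat at one ceiling: the limit of > 10000 nM in this assay, at which 4 of the 4 values shown sit.

The compounds shown leave open how far any of these alkoxyphenyl variations on the shared core lies from that limit, and whether they differ at all.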